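Methoxy in place of methyl on compound 2

A few compounds are considered here, and "the series" means these few. Any claim that something is new, unique, unknown or untested is made for them only; others in the source may bear on it.

In an ADME assay on Caco-2 cells (Homo sapiens) for permeability, read by LC-MS, in the apical to basolateral direction, with a stated time of 60 min, at pH 6.5 (a lower number here means that the compound crosses the layer more slowly, a higher number that the compound crosses the layer faster), compound 1 (`O=C(NCc1cc(Cl)ccc1-n1cnnn1)[C@@H]1C[C@@H]2C[C@@H]2N1C(=O)[C@H](O)C1CCCCC1`) gives 16 10^-6 cm/s and compound 2 (`CC(C)(C)[C@@H](O)C(=O)N1[C@H](C(=O)NCc2cc(Cl)ccc2-n2cnnn2)C[C@@H]2C[C@@H]21`) gives 16 10^-6 cm/s, so the two stand level. Compound 3 (`COC(C)(C)[C@@H](O)C(=O)N1[C@H](C(=O)NCc2cc(Cl)ccc2-n2cnnn2)C[C@@H]2C[C@@H]21`) differs from compound 2 by methoxy in place of methyl on a saturated chain carbon bound to three saturated chain carbons, with methoxy in place of methyl on a saturated chain carbon bound to three saturated chain carbons. Going by the values given here, the one measured step, no change at the digits printed from compound 1 to compound 2 (within the scatter), put tert-butyl in place of cyclohexyl. Among the compounds with values here, no measured step introduces methoxy, so only a slight fall in this assay, within the scatter, is expected. The expected change is a 1.2-fold lower number from compound 2 to compound 3 (0.09 log units; within the scatter). The estimate for compound 3 is 13 10^-6 cm/s, with an expected range of 7 10^-6 cm/s to 22 10^-6 cm/s.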

Compound 3, apparent permeability: 16 10^-6 cm/s
Compound 3: the middle estimate sits 1.2-fold (0.09 log units) below what was measured, within the range that was stated.
By their numbers in this assay, from the lowest: compounds 1, 2 and 3 (each within the scatter of the next).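

In this assay, methoxy in place of methyl on a saturated chain carbon bound to three saturated chain carbons gives no change at the digits printed from compound 2 to compound 3 (within the scatter). Set against cyclohexyl, 1-methoxy-1-methylethyl gives no change at the digits printed from compound 1 to compound 3 (within the scatter), so this position now holds an oxygen-bearing group as well as tert-butyl and cyclohexyl, all at one level. No measured evidence bears on why these values stand level. The compounds shown leave open whether an amine or a carboxylic acid in place of methoxy would stay at that level. From the compounds shown here alone, a longer chain on the same oxygen remains equally open.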